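The source may hold more compounds than are shown below. What is called first, only, known or untested is meant among the compounds shown, and "the series" means these compounds.

Compound 1 is `CCc1cc(S(=O)(=O)N2C[C@H](c3ccccc3)NC2=O)ccc1NC(=O)c1ccc([N+](=O)[O-])cc1`; in a functional assay on NCI-H460 cells (Homo sapiens) for cytotoxicity, read by MTT assay (on this read-out higher numbers stand for weaker inhibition and lower numbers for stronger inhibition), compound 1 gives 800 nM. Compound 2 is `Cc1cc(S(=O)(=O)N2C(=O)N[C@@H](c3ccccc3)C2C)ccc1NC(=O)c1ccc(N)cc1`. In this assay compound 2 gives only a limit, > 10000 nM, and so compound 2 sits at the limit of > 10000 nM in this assay, at which 1 of the 2 values shown sits.

Compound 3 is `Cc1cc(S(=O)(=O)N2C(=O)N[C@@H](c3ccccc3)C2C)ccc1NC(=O)c1ccc([N+](=O)[O-])cc1`, reached from compound 2 by nitro in place of amino on an aromatic carbon. Among the compounds with values here, no measured pair isolates this change; compound 1, which also carries a nitro group, gives a number rather than a limit. Compound 3 is expected to shift toward stronger inhibition by an at least 3.3-fold lower number from compound 2 to compound 3 (0.52 log units; beyond the scatter), the size uncertain. Compound 3 is estimated at 3000 nM, with a range from 700 nM to 15000 nM.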

Compound 3, half-maximal inhibitory concentration: > 10000 nM
Compound 3: a limit, no number; the forecaster's own chance of this, stated with the estimate: 35%; middle value at least 3.3-fold (0.52 log units) from the limit.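

Compound 2 and compound 3 both give only a limit and not a number, so no step can be read between them: the limit of > 10000 nM in this assay, at which 2 of the 3 values shown sit. The compounds shown leave open whether nitro in place of amino changes the result in this assay.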